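The source may hold more compounds than are shown below. What is called first, only, known or untested is meant among the compounds shown, and "the series" means these compounds.

Compound 1 `C=CCNc1nc(NCc2ccc(C(=O)Nc3ccc(F)cc3)cc2)c2ccccc2n1` is the starting point. In a functional assay on SW480 cells (Homo sapiens) for inhibition, read by luminescence and resazurin assay, with a stated time of 3 days (on this read-out higher numbers stand for weaker inhibition and lower numbers for stronger inhibition), compound 1 gives 11000 nM. Compound 2 `C=CCNc1nc(NCc2ccc(C(=O)Nc3ccc(F)cc3)cc2)c2cc(C)ccc2n1` gives 10000 nM, and the step of a 1.1-fold lower number from compound 1 to compound 2 (0.04 log units; within the scatter) is within the scatter, so the two stand together. Compound 3 `CCNc1ncc(C)c(NCc2ccc(NC(=O)c3ccc(F)cc3)cc2)n1` reaches only (the limit of > 20000 nM in this assay, at which 1 of the 3 values shown sits), a limit of the assay rather than a number, so compound 3 gives > 20000 nM as that limit. Compound 4 `CNc1nc(NCc2ccc(C(=O)Nc3ccc(F)cc3)cc2)c2ccccc2n1` is not yet measured; it differs from compound 1 by hydrogen in place of vinyl on a saturated chain carbon bound to a nitrogen on an aromatic ring. No measured step touches this chain; the one step shown, methyl in place of hydrogen on an aromatic carbon, lay within the scatter. The expected step, a 1.1-fold higher number from compound 1 to compound 4 (0.04 log units; within the scatter), is therefore none beyond the scatter. Compound 4 is estimated at 12000 nM, between 5000 nM and 25000 nM.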

Compound 4, half-maximal inhibitory concentration: 4100 nM
Estimate against measurement, compound 4: 2.9-fold (0.47 log units) above; measured number outside the range, below it.
By their numbers in this assay, from the lowest: compound 4; then compounds 2 and 1 (each within the scatter of the next). At a limit, above all of these: compound 3.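

Going from allylamino to methylamino gives a 2.7-fold lower number from compound 1 to compound 4 (0.43 log units; beyond the scatter) in this assay. This is the first change shown that moves the number beyond the scatter, so this chain matters more here than the methyl added on the aromatic carbon, although the step is modest. Nothing shown explains why the smaller group gives the lower number. On these data alone, it also remains open whether a saturated propyl chain or a plain amino group would push the number lower or raise it again.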